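A few compounds are considered here, and "the series" means these few. Any claim that something is new, unique, unknown or untested is made for them only; others in the source may bear on it.

In an ADME assay on CHO cells (Cricetulus griseus) for cytotoxicity, with a stated time of 24 h (on this read-out lower numbers stand for stronger inhibition and higher numbers for weaker inhibition), compound 1 `CC1=CC(=O)[C@H]2C(C)(C)CCC[C@]2(C)[C@H]1/C=C/C1=C[C@H]2O[C@H]1[C@H]1C(=O)C=CC(=O)[C@H]12` gives 8.19 ug/mL. Compound 2 `CC1=CC(=O)[C@H]2C(C)(C)CCC[C@]2(C)[C@H]1CCc1ccoc1` has no single number to stand on, its entry reading "not determined" (no result reported). Compound 3 `CC1=CC(=O)[C@H]2C(C)(C)CCC[C@]2(C)[C@H]1C=O` remains unmeasured. The structural change is formyl in place of 2-(furan-3-yl)ethyl on a saturated ring carbon. With no number for compound 2, the size of this step in this assay cannot be anchored directly. For the measured compounds named here, the only available reference is compound 1 at 8.19 ug/mL, and a higher number, meaning weaker inhibition, is expected beyond the scatter. For compound 3 the estimated value is 30 ug/mL, with an expected range of 10 ug/mL to 90 ug/mL.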

Compound 3, half-maximal inhibitory concentration: 34.9 ug/mL
Compound 3: middle estimate off by 1.2-fold (0.07 log units), on the low side; measured number inside the range.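

For the compounds shown here, compound 2 has no single number in this assay, so no step to compound 3 can be read. As far as these compounds go, what replacing 2-(furan-3-yl)ethyl with formyl does to this read-out stays open. No evidence at hand bears on the result.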